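Series notes: the step from compound 2 to compound 4

This account rests on a few compounds, and the source may have more. Where it says the series, first, only, none or still open, it means among the compounds named here.

Measured compounds:
Compound 1, `O=C(O)Cc1sc(C(c2ccccc2)c2ccccc2)nc1-c1ccccc1`: 80%
Compound 2, `O=C(O)Cc1sc(C(c2ccc(F)cc2)c2ccc(F)cc2)nc1-c1ccnc(F)c1`: 80%
Compound 3, `O=C(O)Cc1sc(C(c2ccccc2)c2ccc(Cl)cc2)nc1-c1ccc(Cl)cc1`: 80%

In an in vitro functional assay on HEK285-7 cells for antagonist activity at prostaglandin D2 receptor 2 (Homo sapiens), read by BRET and beta-arrestin recruitment (on this read-out lower numbers stand for smaller maximal responses and higher numbers for larger maximal responses), compound 1 gives 80%, compound 2 gives 80% and compound 3 gives 80%. Compound 2 thus stands level with compound 1 and with compound 3 at the digits shown; the gaps lie within the scatter, so no order among the three can be read.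

Compound 4, `O=C(O)Cc1sc(C(c2ccc(F)cc2)c2ccc(F)cc2)nc1-c1ccncc1`, is not yet measured. It differs from compound 2 in one place: hydrogen in place of fluoro on an aromatic carbon.

Going by the values given here, no step between measured compounds is available. Three compounds with different substituents all sit at one level in this assay, so no step beyond the scatter is expected here. For compound 4 the expected step is no change at the digits printed from compound 2 to compound 4 (within the scatter). Compound 4 is estimated at 80%, with a range of 66% to 92%.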

Compound 4, largest response reached (reported as efficacy), in percent of the reference or control that the assay uses: 80%
For compound 4 middle estimate and measured number coincide at the digits printed; the measured number falls inside the stated range.
By their numbers in this assay, from the lowest: compounds 1, 2, 3 and 4 (each within the scatter of the next).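

In this assay the change from 2-fluoropyridin-4-yl to pyridin-4-yl gives no change at the digits printed from compound 2 to compound 4 (within the scatter). Going by these compounds alone, this is the first single-place comparison, and it shows that the fluoro next to the ring nitrogen can be replaced by hydrogen with no readable shift in maximal response. Nothing available explains this result.

On these data alone, whether an amine or a methoxy group at this position would stay at the same level remains open. With no step beyond the scatter so far, the compounds shown do not reveal which part of the structure governs the response.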